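The source may hold more compounds than are shown below. What is called first, only, known or untested is meant among the compounds shown, and "the series" means these compounds.

In a functional assay on T98 cells (Homo sapiens) for antiproliferative activity, with a stated time of 5 days (on this read-out higher numbers stand for an effect only at larger amounts of compound and lower numbers for an effect already at smaller amounts), compound 3 `Nc1nc2cc(-c3nn(C[C@H]4CCCO4)c4ncnc(N)c34)ccc2o1` gives 100 nM, level with compound 1 `Nc1nc2cc(-c3nn(CC4OCCO4)c4ncnc(N)c34)ccc2o1` at 100 nM and compound 2 `Nc1nc2cc(-c3nn(CC4CCCO4)c4ncnc(N)c34)ccc2o1` at 100 nM. The next structure is compound 4 `CCOC(Cn1nc(-c2ccc3oc(N)nc3c2)c2c(N)ncnc21)OCC`, which has not yet been measured. Its structural change from compound 3 is diethoxymethyl in place of oxolan-2-yl on a saturated chain carbon bound to an aromatic nitrogen.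

For the measured compounds named here, two measured steps bear most directly on this change, since both alter the group at the same place. They exchange 1,3-dioxolan-2-yl for oxolan-2-yl, and they read no change at the digits printed from compound 1 to compound 2 (within the scatter) and no change at the digits printed from compound 1 to compound 3 (within the scatter). A third step concerns (the fact that one of compounds 2 and 3 is drawn with a defined configuration and the other without, at the place where they differ), and it reads no change at the digits printed from compound 2 to compound 3 (within the scatter). All three are therefore of no measurable size. However, each of these compounds keeps a ring in the group, whereas diethoxymethyl has none, so the new change goes beyond what they test. On the evidence of the steps to compound 3, no step beyond the scatter is expected in this assay, and no direction can be firmly assigned. The expected step is a 1.2-fold higher number from compound 3 to compound 4 (0.08 log units; within the scatter). For compound 4 the estimated value is 120 nM, with an expected range from 40 nM to 350 nM.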

Compound 4, half-maximal effective concentration: 100 nM
Estimate against measurement, compound 4: 1.2-fold (0.08 log units) above; measured number inside the range.
By their numbers in this assay, from the lowest: compounds 1, 2, 3 and 4 (each within the scatter of the next).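

In this assay, opening the ring leaves the read-out level: no change at the digits printed from compound 3 to compound 4 (within the scatter), and the same holds for no change at the digits printed from compound 2 to compound 4 (within the scatter) and for no change at the digits printed from compound 1 to compound 4 (within the scatter). The earlier compounds shown here had tested only ring-bearing groups on a saturated chain carbon bound to an aromatic nitrogen, whereas compound 4 shows that a group with no ring, diethoxymethyl, reads the same at this place, even with its larger count of heavy atoms and without the defined stereocentre of oxolan-2-yl. Nothing available accounts for this flat reading, so no cause can be assigned to it.

All the groups shown at this place carry oxygen, so it remains open whether an amine, a carboxylic acid or a plain alkyl chain such as butyl would also leave the read-out level. Also open, on these data alone, are how the mirror-image configuration of the oxolan-2-yl group in compound 3 would read and whether the level result extends beyond these cells.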